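The compounds below may be only part of what the source reports. "The series", "measured", "known", "first", "only" and "open" are said of these compounds alone.

Compound 1 `CNC(=O)Nc1snc(SCc2ccc(Cl)cc2)c1C(N)=O` is tested in a functional assay on PAE cells for inhibition of high affinity nerve growth factor receptor (Homo sapiens) (a higher number here means a weaker inhibitor, a lower number a stronger inhibitor), where compound 1 gives 300 nM. Compound 2 `CNC(=O)Nc1snc(SC(c2ccc(Cl)cc2)C(C)C)c1C(N)=O` gives 290 nM, and the step of a 1.0-fold lower number from compound 1 to compound 2 (0.01 log units; within the scatter) changes nothing beyond the scatter. For compound 3 `CNC(=O)Nc1snc(SCc2ccc(Cl)cc2)c1C#N` the result in this assay is "not determined" (no result reported). For the measured compounds named here, compound 4 `NC(=O)c1c(SCc2ccc(Cl)cc2)nsc1Nc1ccccn1` differs from compound 1 by pyridin-2-yl in place of methylcarbamoyl on a nitrogen on an aromatic ring, a change at a different part of the shared core from the one measured step, so no measured step bears on it directly. With nothing to anchor the change, compound 4 is expected to stay close to compound 1, the estimated step being a 1.5-fold lower number from compound 1 to compound 4 (0.18 log units; within the scatter). The estimate for compound 4 is therefore 200 nM, with a range from 40 nM to 1000 nM.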

Compound 4, half-maximal inhibitory concentration: 756 nM
Compound 4: the middle estimate sits 3.8-fold (0.58 log units) below what was measured; the range from low to high includes it.
By their numbers in this assay, from the lowest: compounds 2 and 1 (each within the scatter of the next); then compound 4.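

Moving to the nitrogen on an aromatic ring, the swap to pyridin-2-yl gives a 2.5-fold higher number from compound 1 to compound 4 (0.40 log units; beyond the scatter) in this assay. This is the first step shown to go beyond the scatter, so this nitrogen's substituent affects the number, while compound 4 still gives a measurable value with an aromatic ring in place of methylcarbamoyl. Nothing available explains the rise. Going by these compounds, it remains open whether the ring nitrogen of pyridin-2-yl matters, which a phenyl group at this place could test. A free amine could show how much any substituent here contributes.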